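Ring substituent on the triazole nitrogen: cyclopentyl to pyrrolidinyl

The compounds below may be only part of what the source reports. "The series", "measured", "known", "first", "only" and "open" are said of these compounds alone.

Compound 3 `CN1C(=S)[C@@H](NC(=O)c2nc(Cc3ccccc3)n(C3CCCC3)n2)COc2ccccc21` has the highest number of the three in a functional assay on HT-29 cells (Homo sapiens) for inhibition, read by luminescence and CellTiter-Glo, with a stated time of 24 h (a higher number here means that more compound is needed for the effect, a lower number that less compound is needed), giving 3530 nM. Compound 2 `CN1C(=S)[C@@H](NC(=O)c2nc(Cc3ccccc3)n(CCCCC#N)n2)COc2ccccc21` gives 2680 nM, and the pair 2>3 is within the scatter a 1.3-fold higher number from compound 2 to compound 3 (0.12 log units; within the scatter). Compound 1 `CCCCn1nc(C(=O)N[C@H]2COc3ccccc3N(C)C2=S)nc1Cc1ccccc1` gives 510 nM; the step 1>3 is beyond it a 6.9-fold higher number from compound 1 to compound 3 (0.84 log units; beyond the scatter), as is 1>2 a 5.3-fold higher number from compound 1 to compound 2 (0.72 log units; beyond the scatter). Compound 4 `CN1C(=S)[C@@H](NC(=O)c2nc(Cc3ccccc3)n(C3CCNC3)n2)COc2ccccc21` differs from compound 3 only in pyrrolidin-3-yl in place of cyclopentyl on an aromatic nitrogen. Within the data shown here, no measured step introduces a ring nitrogen or a hydrogen-bond donor at this position; the steps 1>3 and 2>3 show only that a cyclopentyl sits at the weak end of the series. Compound 4 is therefore expected to stay near compound 3, with no step beyond the scatter a 1.1-fold higher number from compound 3 to compound 4 (0.05 log units; within the scatter). The estimate for compound 4 in this assay is 4000 nM, range 1500 nM to 12000 nM.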

Compound 4, half-maximal effective concentration: 1070 nM
Compound 4: middle estimate off by 3.7-fold (0.57 log units), on the high side, and the stated range ends above it.
By their numbers in this assay, from the lowest: compound 1; then compound 4; then compounds 2 and 3 (each within the scatter of the next).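

In this assay, a nitrogen in the five-membered ring on the aromatic nitrogen, bringing a hydrogen-bond donor and acceptor, lowers the number relative to the all-carbon ring (a 3.3-fold lower number from compound 3 to compound 4 (0.52 log units; beyond the scatter)). Pyrrolidin-3-yl also improves on 4-cyanobutyl (a 2.5-fold lower number from compound 2 to compound 4 (0.40 log units; beyond the scatter)) but does not match butyl (a 2.1-fold higher number from compound 1 to compound 4 (0.32 log units; beyond the scatter)), so a ring here need not sit at the weak end, while butyl keeps the lowest number. Nothing at hand explains these steps.

Still open, from the compounds shown here alone, is whether the ring nitrogen's hydrogen matters, which a methyl on that nitrogen would test. Also open, going by these compounds, is how a butyl chain ending in a primary amine or a six-membered piperidin-4-yl ring would compare.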